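An aryl swap on the amide nitrogen of compound 3

This account rests on a few compounds, and the source may have more. Where it says the series, first, only, none or still open, it means among the compounds named here.

In a functional assay on T47D cells (Homo sapiens) for inhibition, read by CCK-8 assay, with a stated time of 72 h, tested at 10 uM (a lower number here means less inhibition of growth, a higher number more inhibition of growth at the concentration tested), compound 3 (`CN(C)C(=O)c1cc2cnc(Nc3ccc(NC(=O)C4(C(=O)Nc5ccccc5F)CC4)cc3)nc2n1C1CCCC1`) gives 97.8%. Compound 1 (`CN(C)C(=O)c1cc2cnc(Nc3ccc(NC(=O)C4(C(=O)Nc5ccc(F)cc5)CC4)cc3)nc2n1C1CCCC1`) gives 105%, and compound 2 (`Cc1cccc(NC(=O)C2(C(=O)Nc3ccc(Nc4ncc5cc(C(=O)N(C)C)n(C6CCCC6)c5n4)cc3)CC2)c1`) gives 95.3%, so all three values lie within the scatter of one another. The unmeasured compound 4 (`COc1cccc(NC(=O)C2(C(=O)Nc3ccc(Nc4ncc5cc(C(=O)N(C)C)n(C6CCCC6)c5n4)cc3)CC2)c1`) carries 3-methoxyphenyl in place of 2-fluorophenyl on an amide-type nitrogen. Three measured steps change the aryl group at this same place: a number 9.7 percentage points lower from compound 1 to compound 2 (within the scatter), a number 7.2 percentage points lower from compound 1 to compound 3 (within the scatter) and a number 2.5 percentage points higher from compound 2 to compound 3 (within the scatter). None of them leaves the scatter, so no step beyond the scatter is expected here. The expected step is a number 1.8 percentage points lower from compound 3 to compound 4 (within the scatter). The estimated value for compound 4 is 96%, within an expected range of 84% to 106%.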

Compound 4, percent growth inhibition at one concentration: 93.5%
Beside the measured number, compound 4's estimate is 2.5 percentage points above it, within the range that was stated.
By their numbers in this assay, from the lowest: compounds 4, 2, 3 and 1 (each within the scatter of the next, the first and the last beyond it).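

In this assay, 3-methoxyphenyl on this amide-type nitrogen holds up: a number 4.3 percentage points lower from compound 3 to compound 4 (within the scatter) and a number 1.8 percentage points lower from compound 2 to compound 4 (within the scatter) both stay within the scatter. Among these compounds, the only step at this place to leave the scatter is a number 11.5 percentage points lower from compound 1 to compound 4 (beyond the scatter), and it is modest, so the earlier picture of fully interchangeable aryl groups no longer holds for every pair. No other measurement bears on this result. Going by these compounds, all four compounds carry a substituted phenyl here, so it remains open whether an amine or a carboxylic acid on that ring, or a saturated ring in its place, would keep this level of growth inhibition.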